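This account rests on a few compounds, and the source may have more. Where it says the series, first, only, none or still open, it means among the compounds named here.

Measured compounds:
compound 1 `COC(=O)c1scc(-c2ccc(NC(=O)c3cc(I)ccc3F)cc2)c1OC` — 45300 nM
compound 2 `COC(=O)c1scc(-c2ccc(NC(=O)c3ccc(C#N)nc3)cc2)c1OC` — "not determined" (no result reported)
compound 3 `COC(=O)c1scc(-c2ccc(NC(=O)c3cccc(C(F)(F)F)c3)cc2)c1OC` — "not determined" (no result reported)

The series shares one core, carried through all three compounds, and varies only the aryl group attached to the amide. Among the measured compounds shown here, in an ADME assay on HEK293 cells (Homo sapiens) for cytotoxicity, read by MTT assay, with a stated time of 24 h (a lower number here means a stronger inhibitor, a higher number a weaker inhibitor), compound 1 gives 45300 nM, the sole number available. Compound 2 gives "not determined" (no result reported), and compound 3 stands in the same position with "not determined" (no result reported): no single number exists for it, and one further member of the set is in the same situation. Compound 3 therefore has nothing of its own to measure against; only compound 1 offers a point of reference for how this core behaves in this assay.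

The next compound, compound 4 `COC(=O)c1scc(-c2ccc(NC(=O)c3cccc(I)c3)cc2)c1OC`, differs from compound 3 by a single exchange: iodo in place of trifluoromethyl on an aromatic carbon. For the measured compounds named here, no step between measured compounds is available for this change, so there is nothing in the data on which a shift could rest. Going by the values given here, the one number that does exist belongs to compound 1 and is weak, and compound 4 is expected to fall in a similar region, with any movement from compound 3 not beyond the scatter. Compound 4 is estimated to give 45000 nM, within 15000 nM to 120000 nM.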

Compound 4, half-maximal inhibitory concentration: 42700 nM
The estimate for compound 4 lay 1.1-fold (0.02 log units) above the measured number; low and high end bracket the measured number.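

In this assay, the series now has its first readable comparison, a 1.1-fold lower number from compound 1 to compound 4 (0.03 log units; within the scatter), and this step, hydrogen in place of fluoro on an aromatic carbon, stays within the usual scatter. With iodo retained on the ring in both compounds, the presence or absence of that fluoro makes no discernible difference to the read-out on this shared core. The exchange of trifluoromethyl for iodo, meta to a large group, cannot be read, as compound 3 has no single number, and no information is available to explain the likeness of compound 1 and compound 4.

The compounds shown leave open whether any other group at this place, such as an amine, a carboxylic acid or a longer chain like propyl, would move the number beyond the scatter or leave it where compound 1 and compound 4 lie. They also leave open how 3-(trifluoromethyl)phenyl and 3-iodophenyl compare, and whether a stronger reading is possible at all on this core.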